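Adding a methyl to the chain carbon of compound 2

The source may report more compounds than this note shows. Statements on the series, on what has been measured and on what is new or still open speak of the compounds shown alone.

Measured in a functional assay on SNB-19 cells (Homo sapiens) for inhibition, read by MTT assay, with a stated time of 7 days; on this read-out higher numbers stand for weaker inhibition of growth and lower numbers for stronger inhibition of growth:
- compound 1 `C[Si](C)(C)CCOCn1nnc2c(C(N)=O)ncn2c1=O`: 29900 nM
- compound 2 `NC(=O)c1ncn2c(=O)n(Cc3ccccc3)nnc12`: > 50000 nM, a limit
- compound 3 `NC(=O)c1ncn2c(=O)n(Cc3cccs3)nnc12`: > 50000 nM, a limit

Compound 2 stands at the limit of > 50000 nM in this assay, at which 2 of the 3 values shown sit. It therefore has a limit rather than a true number. Compound 4 `C[C@@H](c1ccccc1)n1nnc2c(C(N)=O)ncn2c1=O` differs from it in one place: methyl in place of hydrogen on a saturated chain carbon bound to an aromatic carbon and an aromatic nitrogen.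

Three measured steps offer some guidance, but none of them tests a methyl. The first, an at least 1.6-fold higher number from compound 1 to compound 2 (0.22 log units; that floor lies within the scatter), has a floor within the scatter, as does the second, an at least 1.6-fold higher number from compound 1 to compound 3 (0.22 log units; that floor lies within the scatter). The third, a step that the two limits leave unreadable from compound 2 to compound 3, cannot be read at all. These steps give no size for the new change.

Since compound 2 sits at the limit > 50000 nM, no step beyond the scatter is expected in this assay, and no direction can be expected either. The expected change is a step that the limit leaves unreadable from compound 2 to compound 4. A report of a limit alone is the likeliest outcome. For compound 4 the estimated value is 60000 nM, with an expected range of 30000 nM to 120000 nM.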

Compound 4, concentration for 50% growth inhibition: 34700 nM
Compound 4: middle estimate off by 1.7-fold (0.24 log units), on the high side, within the range that was stated.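

In this assay compound 4 gives a true number, 34700 nM, which neither earlier compound with an aromatic ring on this chain carbon provided. Placing methyl in place of hydrogen on this carbon gives an at least 1.4-fold lower number from compound 2 to compound 4 (0.15 log units; that floor lies within the scatter), so the compounds shown do not establish a real gain in growth inhibition. The full size of the step stays unknown because its starting point is only a limit: the limit of > 50000 nM in this assay, at which 2 of the 4 values shown sit.

Open, from the compounds shown here alone, is whether a larger group on the same carbon, such as ethyl or hydroxymethyl, would move the number clearly beyond the usual scatter, and whether the mirror-image form of compound 4 would match it. Also open, going by these compounds, is whether the same methyl would give a measurable number with the thiophen-2-yl group of compound 3.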